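This account rests on a few compounds, and the source may have more. Where it says the series, first, only, none or still open, it means among the compounds named here.

Measured so far:
Compound 1, `CC(=O)N[C@@H]1CCN(c2cc(C)nn3c(-c4ccc(C#N)cc4)c(C)nc23)C1`, in an ADME assay on microsomes from liver (Mus musculus) for metabolic stability, read by LC-MS, with NADPH named in the record, with a stated time of 60 min, tested at 1 uM, in the absence of a further agent; on this read-out higher numbers stand for a more stable compound and lower numbers for a less stable compound: compound 1 gives > 95%, a limit of the assay.
Compound 2, `CC(=O)N[C@@H]1CCN(c2cc(C)nn3c(-c4cccc(S(=O)(=O)N(C)C)c4)c(C)nc23)C1`: compound 2 gives > 95%, again a limit.
Compound 3, `COc1ccc(-c2c(C)nc3c(N4CC[C@@H](NC(=O)OC5CCCCC5)C4)cc(C)nn23)cc1OC`: compound 3 gives > 95%, also a limit.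

Compound 3 therefore stands at the upper limit of this assay rather than at a number, and it does so together with the two other compounds, because of the limit of > 95% in this assay, at which 3 of the 3 values shown sit. Among the measured compounds shown here, no pair among the three differs in a single place, so no measured step is available to lean on, and the three values say only that each compound sits at the limit.

Compound 4, `COc1ccc(-c2c(C)nc3c(N4CC[C@@H](NS(=O)(=O)c5ccc(C#N)cc5)C4)cc(C)nn23)cc1OC`, is the next compound. It differs from compound 3 in one place: (4-cyanophenyl)sulfonyl in place of cyclohexyloxycarbonyl on an amine nitrogen. For the measured compounds named here, with no measured step for guidance, the account expects for compound 4 a step that stays within the usual scatter, which is what a number at least 5 percentage points lower from compound 3 to compound 4 (that floor lies within the scatter) means. Compound 4 is accordingly estimated to give 90%, with a range from 72% to 99%, in this assay.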

Compound 4, percent of the compound remaining: > 95%
Compound 4 was reported as a limit; the forecaster's own chance of this, stated with the estimate: 55%; middle value at least 5 percentage points away from the limit.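

No new step can be read between compound 3 and compound 4, because both sit at the same limit: the limit of > 95% in this assay, at which 4 of the 4 values shown sit.

The compounds shown leave open whether (4-cyanophenyl)sulfonyl and cyclohexyloxycarbonyl on that amine nitrogen differ at all in this assay, where none of the four yet has a number.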